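The compounds below may be only part of what the source reports. "The series", "measured", "known", "first", "only" and "open" are said of these compounds alone.

Measured so far in a physicochemical assay for lipophilicity, read by HPLC, at pH 7.5; on this read-out lower numbers stand for lower lipophilicity and higher numbers for higher lipophilicity
Compound 1 `CCOc1ccccc1-c1ccc(-c2nc3cnccc3c(NC(C)C(=O)O)c2C#N)cc1` gives 2.1
Compound 2 `CC[C@@H](Nc1c(C#N)c(-c2ccc(-c3cccc(C)c3F)cc2)nc2cnccc12)C(N)=O` gives 3

In this assay compound 1 (2.1) stands lowest of the two measured compounds, and the value of compound 2 (3) lies higher by a gap beyond the usual scatter. Compound 3 (`CCCCC(Nc1c(C#N)c(-c2ccc(-c3ccccc3OCC)cc2)nc2cnccc12)C(N)=O`) has yet to be measured. It differs from compound 1 in one place, on a nitrogen on an aromatic ring, where 1-carbamoylpentyl stands in place of 1-carboxyethyl (1-carbamoylpentyl in place of 1-carboxyethyl on a nitrogen on an aromatic ring). Going by the values given here, no pair of measured compounds shows this change alone, so its size remains uncertain. Compound 2, which also carries a carbamoyl group but differs elsewhere too, reads higher (3), and this supports expecting a rise beyond the scatter. The expected step is estimated as follows (a number 1.50 log units higher from compound 1 to compound 3 (beyond the scatter)). The estimate for compound 3 is (3.6), with an expected range from 3 to (4.2).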

Compound 3, distribution coefficient: 3.6
For compound 3 middle estimate and measured number coincide at the digits printed, and the stated range covers the measured number.
By their numbers in this assay, from the lowest: compound 1; then compound 2; then compound 3.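

In this assay, going by these compounds alone, putting 1-carbamoylpentyl in place of 1-carboxyethyl on a nitrogen on an aromatic ring gives a number 1.50 log units higher from compound 1 to compound 3 (beyond the scatter) as a large step, and this is the first reading of a change made at this position alone. It shows that, with the rest of the compound unchanged, the group on this nitrogen can by itself move the read-out well beyond the scatter. The data offer no measured evidence on what lies behind this step.

The step combines two differences, a carboxylic acid giving way to a primary amide and a longer chain, and the compounds shown do not separate their shares. Going by these compounds, how much each contributes remains open, and a 1-carbamoylethyl or a 1-carboxypentyl group on the same nitrogen would divide the step into its parts.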